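Swapping Chloro for Iodo on a Thiophene

A few compounds are considered here, and "the series" means these few. Any claim that something is new, unique, unknown or untested is made for them only; others in the source may bear on it.

In a functional assay on HUVEC cells (Homo sapiens), read by BrdU incorporation, with a stated time of 72 h (a lower number here means a stronger inhibitor, a higher number a weaker inhibitor), compound 2 `Cc1ccc2nc(Cl)c(/C=C/C(=O)c3ccc(Cl)s3)cc2c1` gives 59.4 nM. Among the measured compounds shown here, the only other number comes from compound 3 `Cc1ccc2cc(/C=C/C(=O)c3ccc(Br)s3)c(Cl)nc2c1`, which gives 83.6 nM. These two values lie within the scatter of each other, so the data do not separate them, and compound 2 simply sits level with compound 3. A third relative, compound 1 `Cc1cc(C(=O)/C=C/c2cc3cccc(C)c3nc2Cl)c(C)s1`, offers no number to compare: its entry reads "not determined" (no result reported).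

The next molecule to be tested is compound 4 `Cc1ccc2nc(Cl)c(/C=C/C(=O)c3ccc(I)s3)cc2c1`. It keeps everything in compound 2 except one atom, and the change is iodo in place of chloro on an aromatic carbon. This turns the 5-chlorothiophen-2-yl group into a 5-iodothiophen-2-yl group, with the iodo on an aromatic carbon next to the ring sulfur.

For the measured compounds named here, no pair of measured compounds differs in just one place, so there is no measured step to use as a guide. The expectation therefore rests on compound 2 at 59.4 nM and on the single-atom size of the change. The expected shift is small, toward a slightly higher number and not beyond the scatter, with an estimated 1.3-fold higher number from compound 2 to compound 4 (0.13 log units; within the scatter). For compound 4 the estimate is 80 nM, with an expected range of 30 nM to 200 nM.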

Compound 4, half-maximal inhibitory concentration: 129 nM
Compound 4: the middle estimate sits 1.6-fold (0.21 log units) below what was measured; low and high end bracket the measured number.
By their numbers in this assay, from the lowest: compounds 2, 3 and 4 (each within the scatter of the next, the first and the last beyond it).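

Among the compounds shown here, this is the first step in which only one atom changes, and it shows that the group on this aromatic carbon next to the ring sulfur is not a silent spot: in this assay, iodo in place of chloro gives a 2.2-fold higher number from compound 2 to compound 4 (0.34 log units; beyond the scatter), which lies beyond the scatter and points toward a weaker inhibitor. The step is modest, though, so the exchange does not abolish inhibition, and compound 4 still gives 129 nM. Nothing measured here explains the shift, so the reason for the higher number stays unknown.

Compound 3 carries a bromo on its thiophene, but its core also differs from that of compound 2, so it cannot show how a bromo at this place would compare on the same core. Also open, from the compounds shown here alone, is how this position responds to groups other than halogens, such as a methyl, a methoxy or a nitrile, or to a plain hydrogen, which would show whether a halogen is needed there at all.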